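The source may hold more compounds than are shown below. What is called first, only, known or untested is meant among the compounds shown, and "the series" means these compounds.

Compound 1 `C[C@H]1O[C@@H](n2cnc3c(N)nc(N=[N+]=[N-])nc32)[C@H](O)[C@@H]1O` and compound 2 `CS[C@H]1O[C@@H](n2cnc3c(N)nc(N=[N+]=[N-])nc32)[C@H](O)[C@@H]1O` share one core. In an ADME assay on L6 cells (Rattus norvegicus) for cytotoxicity (on this read-out higher numbers stand for weaker inhibition and lower numbers for stronger inhibition), compound 1 gives 181000 nM, and compound 2 gives 236000 nM. The change between them, (methylsulfanyl in place of methyl on a saturated ring carbon), made a step of a 1.3-fold higher number from compound 1 to compound 2 (0.12 log units; within the scatter). Compound 3 `CNc1nc(C#N)nc2c1ncn2[C@@H]1O[C@H](C)[C@@H](O)[C@H]1O` rests on a different core; how its core differs from that of compound 1 is not broken down here. In this assay compound 3 gives 85000 nM, the lowest of the three numbers. Compound 4 `CNc1nc(C#N)nc2c1ncn2[C@@H]1O[C@H](SC)[C@@H](O)[C@H]1O` has not yet been measured; it differs from compound 3 by methylsulfanyl in place of methyl on a saturated ring carbon, the same change, at the same place, as that between compound 1 and compound 2. Because the step of a 1.3-fold higher number from compound 1 to compound 2 (0.12 log units; within the scatter) stayed within the scatter, compound 4 is expected to show a step of a 1.3-fold higher number from compound 3 to compound 4 (0.11 log units; within the scatter). The estimate for compound 4 is 110000 nM, expected to lie between 50000 nM and 250000 nM.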

Compound 4, half-maximal inhibitory concentration: 24000 nM
Compound 4: the middle estimate sits 4.6-fold (0.66 log units) above what was measured; the whole stated range lies above it.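

On the core of compound 3, methylsulfanyl in place of methyl gives a 3.5-fold lower number from compound 3 to compound 4 (0.55 log units; beyond the scatter) in this assay, so the number falls and inhibition in these cells becomes stronger. The same change therefore did not carry over as a matching step from one core to the other: the same change on two cores in this assay, a 1.3-fold higher number (0.12 log units; within the scatter) from compound 1 to compound 2 and a 3.5-fold lower number (0.55 log units; beyond the scatter) from compound 3 to compound 4, 4.6-fold (0.66 log units) apart, beyond the scatter of two such steps This shows that, among these compounds, a step read on one core is a poor guide to the step on the other, but two pairs do not show which difference between the cores matters or what a further core would do.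

From the compounds shown here alone, it remains open how a longer chain such as ethylsulfanyl, or an amine, would behave in place of methyl on that saturated ring carbon. Going by these compounds, it also remains open whether either group would follow the step on the core of compound 1 or the one on the core of compound 3.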